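The source may hold more compounds than are shown below. What is called first, only, known or untested is meant among the compounds shown, and "the series" means these compounds.

Series notes on a physicochemical assay for acid dissociation. Compound 1 `COc1ccc(F)cc1CNCCCNc1ccnc2cc(Cc3cc(C)cc(C)c3)ccc12` gives 9.47, compound 3 `COc1ccc(F)cc1CNCCCNc1ccnc2cc(C3CCCCC3)ccc12` gives 9.47, and compound 2 `c1ccc(Oc2ccc3c(NCCCNCc4ccco4)ccnc3c2)cc1` gives 9.28; the number for compound 2 lies within the scatter of both others, so the three stand together. Compound 4 `CC(C)CCc1ccc2c(NCCCNCc3ccco3)ccnc2c1` differs from compound 2 by isopentyl in place of phenoxy on an aromatic carbon. For the measured compounds named here, the one measured step that bears on it, no change at the digits printed from compound 1 to compound 3 (within the scatter), exchanges a group on an aromatic carbon of the shared core and leaves this assay unmoved. The change in compound 4 is of the same kind, remote from the amines, so no step beyond the scatter is expected, a number 0.02 log units higher from compound 2 to compound 4 (within the scatter). Compound 4 is therefore estimated at 9.3, in the range 9 to 9.6.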

Compound 4, acid dissociation constant: 9.47
Estimate against measurement, compound 4: 0.17 log units below; low and high end bracket the measured number.
By their numbers in this assay, from the lowest: compounds 2, 1, 3 and 4 (each within the scatter of the next).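

In this assay isopentyl in place of phenoxy on an aromatic carbon gives a number 0.19 log units higher from compound 2 to compound 4 (within the scatter) and so removes a six-membered aromatic ring and a hydrogen-bond acceptor without a step beyond the scatter. The earlier step exchanged cyclohexyl for 3,5-dimethylbenzyl, and neither of those groups is linked through oxygen, so this result extends the flat reading to a change of linking atom. No measurement at hand accounts for this flatness. Phenoxy and isopentyl both carry no net charge, so whether an amine or a carboxylic acid at this aromatic carbon would shift the number remains open.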